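The compounds below may be only part of what the source reports. "The series", "measured", "known", "first", "only" and "open" are said of these compounds alone.

Notes on the series, read in an ADME assay on BJ cells (Homo sapiens) for cytotoxicity, with a stated time of 72 h; on this read-out higher numbers stand for an effect only at larger amounts of compound and lower numbers for an effect already at smaller amounts. Compound 1 (`CCc1ccc(-c2nc3c(c(C)nn3-c3ccccc3)c(-c3ccccc3C(F)(F)F)c2C#N)cc1`) gives > 20000 nM, which is a limit and not a number. Compound 2 (`CCc1ccc(-c2nc3c(c(C)nn3-c3ccccc3)c(-c3ccc(O)cc3)c2C#N)cc1`) gives > 20000 nM, also a limit, so it has no exact position on the scale. The two compounds share one reading: the limit of > 20000 nM in this assay, at which 2 of the 2 values shown sit. Within the data shown here, the only measured step, a step that the two limits leave unreadable from compound 1 to compound 2, therefore gives no size to carry forward.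

Compound 3 (`CCc1ccc(-c2nc3c(c(C)nn3-c3ccccc3)c(-c3ccccc3C(=O)OC)c2C#N)cc1`) differs from compound 2 at one place, on the aromatic carbon ortho to a cyano group and opposite the ring nitrogen: 2-(methoxycarbonyl)phenyl in place of 4-hydroxyphenyl on an aromatic carbon. Its 2-(methoxycarbonyl)phenyl group replaces 4-hydroxyphenyl. No step beyond the usual scatter is expected in this assay, and no direction can be assigned, because the limit of > 20000 nM in this assay, at which 2 of the 2 values shown sit, covers compound 1 and compound 2, and both the 2-(trifluoromethyl)phenyl and the 4-hydroxyphenyl analogue sit there. A report at the same limit is the likeliest outcome. The expected change is a number no higher from compound 2 to compound 3 (the limit leaves the size open). Compound 3 is estimated at 20000 nM, with an expected range of 10000 nM to 40000 nM.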

Compound 3, half-maximal effective concentration in the BJ assay: > 20000 nM
Compound 3: a limit, no number; the forecaster's own chance of this, stated with the estimate: 85%; the middle value sits exactly at the limit.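

In the BJ assay, no new step can be read among compound 1, compound 2 and compound 3, since each reading is a limit and not a number: the limit of > 20000 nM in the BJ assay, at which 3 of the 3 values shown sit.

In the BJ assay compound 2 gives > 20000 nM, which is a limit. In the BJ assay compound 3 gives > 20000 nM, which is a limit.

The compounds shown leave open whether 2-(trifluoromethyl)phenyl, 4-hydroxyphenyl and 2-(methoxycarbonyl)phenyl differ at all in the BJ assay, and in which direction.

In a physicochemical assay for solubility, read by spectrophotometry, in phosphate buffer, with a stated time of 18 h, at pH 7.4 (on this read-out higher numbers stand for higher solubility and lower numbers for lower solubility), compound 2 gives 5700 nM and compound 3 gives 17000 nM. In the physicochemical assay the step with 2-(methoxycarbonyl)phenyl in place of 4-hydroxyphenyl is a 3.0-fold higher number from compound 2 to compound 3 (0.47 log units; beyond the scatter).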